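Swapping a trichlorophenyl ether for a dichlorophenyl ether

This account rests on a few compounds, and the source may have more. Where it says the series, first, only, none or still open, it means among the compounds named here.

The shared core of compound 1 `NC1=NC2(CCOCC2)N(OCCCOc2ccc(Cl)c(Cl)c2)C(N)=N1` carries its aryl ether through a three-carbon linker, and in a functional assay on HepG2 cells (Homo sapiens) for antiproliferative activity, read by MTT assay, with a stated time of 72 h (on this read-out lower numbers stand for stronger inhibition and higher numbers for weaker inhibition), compound 1 gives 380 nM. Compound 2 `NC1=NC2(CCOCC2)N(OCCCOc2cc(Cl)c(Cl)cc2Cl)C(N)=N1` keeps that core and linker while bearing a 2,4,5-trichlorophenyl on the oxygen; in this assay compound 2 gives "not determined" (no result reported), so there is no number on which to place it against compound 1, and nothing can be said of how the two compare. Compound 3 `NC1=NC2(CCOCC2)N(OCCCOc2cccc(Cl)c2Cl)C(N)=N1` is the untested neighbour, differing from compound 2 only by 2,3-dichlorophenyl in place of 2,4,5-trichlorophenyl on an oxygen on a saturated carbon. Among the compounds with values here, no measured step frames this change, and with compound 1 as the nearest anchor the step in this assay is expected to be small, none beyond the usual scatter in either direction. Compound 3 is therefore estimated at 400 nM, with a range from 150 nM to 1200 nM.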

Compound 3, half-maximal inhibitory concentration: 330 nM
Beside the measured number, compound 3's estimate is 1.2-fold (0.08 log units) above it; measured number inside the range.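

In this assay, 2,3-dichlorophenyl in place of 3,4-dichlorophenyl on an oxygen on a saturated carbon gives a 1.2-fold lower number from compound 1 to compound 3 (0.06 log units; within the scatter), so the two dichlorophenyl groups cannot be told apart on this read-out. Compound 2 has no number, so its steps to the other compounds cannot be read, and the 2,4,5-trichlorophenyl group remains unplaced against either dichlorophenyl group. Nothing measured here offers an explanation for the result.

The compounds shown leave open whether chlorine on the ring is needed at all, a question that a plain phenyl or a 4-fluorophenyl at this place would address. They also leave open whether a longer chain in place of the present linker would hold the activity in this assay.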